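A few compounds are considered here, and "the series" means these few. Any claim that something is new, unique, unknown or untested is made for them only; others in the source may bear on it.

Working notes on the series in an ADME assay on HEK293 cells (Homo sapiens) for cytotoxicity, read by MTT assay, with a stated time of 72 h; on this read-out lower numbers stand for stronger inhibition and higher numbers for weaker inhibition. Compound 1 `COc1ccc(C2=C(c3cc(OC)c(OC)c(OC)c3)C(=O)C(O)C2)cc1` gives 6.3 ug/mL in this assay. Compound 3 `COc1ccc(C2=C(c3cc(OC)c(OC)c(OC)c3)C(=O)C(O[SiH2]C(C)(C)C)C2)cc1` carries a group of 5 heavy atoms (4 carbon, 1 silicon; no ring) in place of a hydrogen atom, on an oxygen on a saturated carbon and in this assay gives only a limit, > 100 ug/mL. The step of an at least 15-fold higher number from compound 1 to compound 3 (1.20 log units; beyond the scatter) runs up to the limit of > 100 ug/mL in this assay, at which 2 of the 3 values shown sit. Compound 2 `COc1ccc(C2=C(c3cc(OC)c(OC)c(OC)c3)CC(O)C2=O)cc1[N+](=O)[O-]` has a core whose difference from the core of compound 1 is not broken down here. In this assay compound 2 gives only a limit, > 100 ug/mL. Compound 4 `COc1ccc(C2=C(c3cc(OC)c(OC)c(OC)c3)CC(O[SiH2]C(C)(C)C)C2=O)cc1[N+](=O)[O-]`, not yet measured, carries the same change on the core of compound 2, namely (a group of 5 heavy atoms (4 carbon, 1 silicon; no ring) in place of a hydrogen atom, on an oxygen on a saturated carbon). In this assay the estimated step is a step that the limit leaves unreadable from compound 2 to compound 4. That expectation rests on the step of an at least 15-fold higher number from compound 1 to compound 3 (1.20 log units; beyond the scatter) ending at the limit of > 100 ug/mL in this assay, at which 2 of the 3 values shown sit, and on compound 2 already sitting at the limit of > 100 ug/mL in this assay, at which 2 of the 3 values shown sit. Compound 4 is therefore expected at about 150 ug/mL, between 70 ug/mL and 400 ug/mL, most likely again reported only as a limit.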

Compound 4, half-maximal inhibitory concentration: > 100 ug/mL
Compound 4: no number, only a limit (the forecaster's own chance of this, stated with the estimate: 85%); the middle value does not contradict the limit.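

Compound 2 and compound 4 both give only a limit in this assay, so the step between them cannot be read. The compounds shown leave open whether this group of 5 heavy atoms changes the read-out on the core of compound 2.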